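Cyclopentyl for Cyclohexyl: One Step from Compound 1

The compounds below may be only part of what the source reports. "The series", "measured", "known", "first", "only" and "open" are said of these compounds alone.

compound 1 `CCC(C)C(NC(=O)n1nnc2ccccc21)C(=O)NC1CCCCC1` — 63900 nM
compound 2 `CC(C)C(NC(=O)NO)C(=O)NC1CCCCC1` — > 100000 nM (a limit of the assay)
compound 3 `CC(C)C(NC(=O)NO)C(=O)NC1CCCC1` — > 100000 nM (a limit of the assay)

Among the compounds with values here, in a functional assay on HeLa cells (Homo sapiens) for inhibition (a lower number here means a stronger inhibitor, a higher number a weaker inhibitor), compound 1 gives 63900 nM, the only number among the three. The entry for compound 2 is a limit of the assay, not a number. The entry for compound 3 is likewise a limit. Compound 4 `CCC(C)C(NC(=O)n1nnc2ccccc21)C(=O)NC1CCCC1` has not been measured. It differs from compound 1 by cyclopentyl in place of cyclohexyl on an amide-type nitrogen. The same change appears in the step that the two limits leave unreadable from compound 2 to compound 3, which stays unreadable because of the limit of > 100000 nM in this assay, at which 2 of the 3 values shown sit. No readable step therefore bears on the change, and compound 4 is expected to sit close to compound 1, with a step of a 1.1-fold higher number from compound 1 to compound 4 (0.04 log units; within the scatter) expected to remain within the scatter. Compound 4 is estimated at 70000 nM, between 25000 nM and 200000 nM.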

Compound 4, half-maximal inhibitory concentration: 82300 nM
Compound 4: the middle estimate sits 1.2-fold (0.07 log units) below what was measured; the measured number falls inside the stated range.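

In this assay, cyclopentyl in place of cyclohexyl on an amide-type nitrogen now gives a readable result: a 1.3-fold higher number from compound 1 to compound 4 (0.11 log units; within the scatter). At this place on the core of compound 1, the two rings are therefore not told apart. The same change from compound 2 to compound 3 still cannot be read, because both entries are limits of the assay: the limit of > 100000 nM in this assay, at which 2 of the 4 values shown sit.

The compounds shown leave open whether a smaller group such as methyl, an open chain such as n-hexyl, or a ring carrying an amine or a carboxylic acid would give a step beyond the scatter here.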